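Swapping Chloro for Fluoro on a Non-Toxic Scaffold

The source may hold more compounds than are shown below. What is called first, only, known or untested is meant among the compounds shown, and "the series" means these compounds.

Compound 1 `CS(=O)(=O)CCCn1c(Cn2c(=O)n(C3CC3)c3ccncc32)cc2cc(Cl)ccc21` was tested in an ADME assay on HeLa cells (Homo sapiens) for cytotoxicity, read by ATP content, with a stated time of 3 days; a lower number here means that less compound is tolerated, a higher number that more compound is tolerated. In this assay compound 1 gives > 50000 nM, which is a limit of the assay rather than a number. Two close neighbours of compound 1 give the same kind of result. Compound 2 `O=c1n(Cc2cc3cc(Cl)ccc3n2CCCC(F)(F)F)c2cnccc2n1C1CC1` gives > 50000 nM in this assay, again a limit. Compound 3 `CS(=O)(=O)CCCn1c(Cn2c(=O)[nH]c3ccncc32)cc2cc(Cl)ccc21` gives > 50000 nM in this assay, also a limit. The step that the two limits leave unreadable from compound 1 to compound 2 and the step that the two limits leave unreadable from compound 1 to compound 3 therefore cannot be sized, because of the limit of > 50000 nM in this assay, at which 3 of the 3 values shown sit.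

Compound 4 `CS(=O)(=O)CCCn1c(Cn2c(=O)n(C3CC3)c3ccncc32)cc2cc(F)ccc21` differs from compound 1 in a single place: fluoro in place of chloro on an aromatic carbon. Neither of the measured steps touches this part of the molecule, and neither gives a readable size, so nothing here points to a shift beyond the scatter in this assay. Compound 4 is accordingly expected to sit near 70000 nM in this assay, within a range from 35000 nM to 150000 nM, and most probably to be reported only as a limit once more. The expected step that the limit leaves unreadable from compound 1 to compound 4 thus amounts to no change beyond the scatter.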

Compound 4, half-maximal cytotoxic concentration: > 50000 nM
Compound 4 gave a limit, no number (the forecaster's own chance of this, stated with the estimate: 85%); the middle value is on the limit's open side.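

In this assay compound 4 gives > 50000 nM, a limit and not a number. The step from chloro to fluoro between compound 1 and compound 4 therefore has no readable size: the limit of > 50000 nM in this assay, at which 4 of the 4 values shown sit.

The compounds shown leave open at what concentration any of them becomes toxic to these cells, and so whether chloro and fluoro differ here at all.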